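Adding a chloro group on the phenyl ring of compound 3

This account rests on a few compounds, and the source may have more. Where it says the series, first, only, none or still open, it means among the compounds named here.

Measured compounds:
- compound 1 `COc1cc2c(Oc3ccc(NC(=O)c4cc(-c5ccccc5)nc5ccc(F)cc45)cc3F)ccnc2cc1OCCCN1CCCCC1`: 690 nM
- compound 2 `COc1cc2c(Oc3ccc(NC(=O)c4cc(-c5cccc(Cl)c5)nc5ccc(F)cc45)cc3F)ccnc2cc1OCCCN1CCC(C)CC1`: 110 nM
- compound 3 `COc1cc2c(Oc3ccc(NC(=O)c4cc(-c5ccccc5)nc5ccc(F)cc45)cc3F)ccnc2cc1OCCCN1CCCC1`: 960 nM

In a functional assay on U-87MG ATCC cells (Homo sapiens) for cytotoxicity, read by MTT assay, with a stated time of 72 h (on this read-out higher numbers stand for weaker inhibition and lower numbers for stronger inhibition), compound 3 gives the highest of the three numbers. Its nearest neighbour is compound 1, and the move a 1.4-fold higher number from compound 1 to compound 3 (0.14 log units; within the scatter) shows that swapping the ring at the end of the chain makes no real difference. Compound 2, which carries both a chloro group on the phenyl ring and a different ring at the chain end, gives a number well below that of compound 3, a gap beyond the scatter.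

Compound 4 `COc1cc2c(Oc3ccc(NC(=O)c4cc(-c5cccc(Cl)c5)nc5ccc(F)cc45)cc3F)ccnc2cc1OCCCN1CCCC1` keeps the chain end of compound 3 and adds a chloro group: chloro in place of hydrogen on an aromatic carbon. For the measured compounds named here, no measured pair isolates this single change. Going by the values given here, the only direct step, from compound 1 to compound 3, concerns the chain end and lies within the scatter, so the large drop seen in compound 2 against compound 3 is most plausibly carried by the chloro group. A step downward in this assay, beyond the scatter, is therefore expected, as a 4.8-fold lower number from compound 3 to compound 4 (0.68 log units; beyond the scatter). For compound 4 the estimate is 200 nM, with a range from 80 nM to 600 nM.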

Compound 4, half-maximal inhibitory concentration: 990 nM
For compound 4 the middle estimate is 5.0-fold (0.69 log units) below the measured one; measured number above the stated range.
By their numbers in this assay, from the lowest: compound 2; then compounds 1, 3 and 4 (each within the scatter of the next).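

Chloro in place of hydrogen on this aromatic carbon, meta to a large group, gives a 1.0-fold higher number from compound 3 to compound 4 (0.01 log units; within the scatter), so on a chain ending in pyrrolidin-1-yl the change from phenyl to 3-chlorophenyl leaves the number where it was. With 3-chlorophenyl present in both compounds, pyrrolidin-1-yl in place of 4-methylpiperidin-1-yl gives a 9.0-fold higher number from compound 2 to compound 4 (0.95 log units; beyond the scatter), which shows that the chloro group alone does not bring the low number of compound 2 and that the ring at the chain end makes a real difference here. No measurement at hand explains why the chloro group has no visible effect in one setting or why the chain-end ring matters in the other.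

Still open, as far as these compounds go, is whether 4-methylpiperidin-1-yl lowers the number by itself or only together with 3-chlorophenyl, a question that a plain phenyl partner for that ring would settle. Also open, from the compounds shown here alone, is how a morpholine ring at the chain end would read, or a fluoro or methoxy group in the place of the chloro group.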